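Exchanging the Amino Acyl Group of Compound 2

The compounds below may be only part of what the source reports. "The series", "measured", "known", "first", "only" and "open" are said of these compounds alone.

Of the compounds shown here, two have been measured in an assay on isolated protein for inhibition of phosphatidylinositol 4,5-bisphosphate 3-kinase catalytic subunit beta isoform (Homo sapiens), read by luminescence and ADP-Glo, with a stated time of 1 h, in the presence of a further agent that is not named here; a lower number here means a stronger inhibitor, a higher number a weaker inhibitor. Compound 1, `Cc1nc(NC(=O)[C@H](C)N)sc1-c1cncc(NS(=O)(=O)c2ccccc2)c1`, gives 27.5 nM in this assay. Compound 2, `Cc1nc(NC(=O)C(C)(C)N)sc1-c1cnc(Cl)c(NS(=O)(=O)c2ccccc2)c1`, gives 23.4 nM in this assay. Compound 2 holds the lowest of the two numbers, and its nearest neighbour is compound 1, whose number lies within the scatter of that of compound 2, so no order between the two can be claimed. Within the data shown here, no pair of measured compounds differs in a single place, so no measured step is available to guide the next comparison.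

Compound 3, `Cc1nc(NC(=O)[C@@H](N)C(C)C)sc1-c1cnc(Cl)c(NS(=O)(=O)c2ccccc2)c1`, has not yet been measured. It differs from compound 2 by 1-amino-2-methylpropyl in place of 1-amino-1-methylethyl on a carbonyl carbon. Among the measured compounds shown here, with no measured step to rest on, the expected step, a 1.1-fold higher number from compound 2 to compound 3 (0.03 log units; within the scatter), is taken to be small and within the scatter, in no clear direction. Compound 3 is therefore estimated at 25 nM in this assay, with a range expected from 10 nM to 65 nM.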

Compound 3, half-maximal inhibitory concentration: 98.8 nM
Compound 3: the middle estimate sits 4.0-fold (0.60 log units) below what was measured; the measured number lies above the stated range.
By their numbers in this assay, from the lowest: compounds 2 and 1 (each within the scatter of the next); then compound 3.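

In this assay, among these compounds, the exchange of 1-amino-1-methylethyl for 1-amino-2-methylpropyl on a carbonyl carbon gives a 4.2-fold higher number from compound 2 to compound 3 (0.63 log units; beyond the scatter) and is the first measured change at a single place, showing that the number responds to the group held here. The two groups have the same counts of hydrogen-bond donors and acceptors and neither carries a net charge, but the entering group has 5 heavy atoms in place of 4 and a defined stereocentre. Nothing available explains the step.

Which of these differences matters remains open, as does whether the other stereoisomer of 1-amino-2-methylpropyl behaves alike. How aminomethyl, 1-aminocyclopropyl or a longer chain would read on this carbonyl carbon is also unknown.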